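The source may report more compounds than this note shows. Statements on the series, on what has been measured and on what is new or still open speak of the compounds shown alone.

In a functional assay on B16-F10 cells (Homo sapiens) for cytotoxicity against B16-F10 (Mus musculus), read by MTT assay, with a stated time of 72 h (a higher number here means that more compound is needed for the effect, a lower number that less compound is needed), compound 1 `O=C1/C(=C\c2ccc(O)cc2)c2ccccc2N1c1c(Cl)cccc1Cl` gives 33 ug/mL and compound 2 `O=C1/C(=C\c2ccc(F)cc2)c2ccccc2N1c1c(Cl)cccc1Cl` gives 38 ug/mL. These two sit together, with a 1.2-fold higher number from compound 1 to compound 2 (0.06 log units; within the scatter). Compound 3 `CN(C)c1ccc(/C=C2\C(=O)N(c3c(Cl)cccc3Cl)c3ccccc32)cc1` gives > 100 ug/mL, which is a limit of the assay and not a number. Compound 4 `O=C1/C(=C\c2ccccc2Cl)c2ccccc2N1c1c(Cl)cccc1Cl` carries 2-chlorophenyl in place of 4-hydroxyphenyl, on a double-bonded chain carbon bound to a double-bonded ring carbon: 2-chlorophenyl in place of 4-hydroxyphenyl on a double-bonded chain carbon bound to a double-bonded ring carbon. Two measured changes on that aromatic group bear on this. Fluoro for hydroxy gave a 1.2-fold higher number from compound 1 to compound 2 (0.06 log units; within the scatter), while dimethylamino for hydroxy gave an at least 3.0-fold higher number from compound 1 to compound 3 (0.48 log units; beyond the scatter). Neither tests chlorine, so the expectation is loose, and no shift beyond the scatter is expected: a 1.2-fold higher number from compound 1 to compound 4 (0.06 log units; within the scatter). For compound 4 the expected value is 38 ug/mL, with an estimated range of 15 ug/mL to 95 ug/mL.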

Compound 4, concentration for half-maximal effect: 39 ug/mL
Compound 4: the middle estimate sits 1.0-fold (0.01 log units) below what was measured, and the stated range covers the measured number.
By their numbers in this assay, from the lowest: compounds 1, 2 and 4 (each within the scatter of the next). At a limit, above all of these: compound 3.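

In this assay, 2-chlorophenyl can replace 4-hydroxyphenyl, giving up the hydrogen-bond donor and acceptor, with a 1.2-fold higher number from compound 1 to compound 4 (0.07 log units; within the scatter). Replacing 4-fluorophenyl with it gives a 1.0-fold higher number from compound 2 to compound 4 (0.01 log units; within the scatter), so this position tolerates a chlorine carried at the 2-position of the ring as well as these 4-substituted groups. Replacing 4-(dimethylamino)phenyl gives an at least 2.5-fold lower number from compound 3 to compound 4 (0.40 log units; beyond the scatter), though compound 3 is a limit of the assay and not a number: the limit of > 100 ug/mL in this assay, at which 1 of the 4 values shown sits.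

Whether the chlorine's place on the ring matters stays open, since 4-chlorophenyl is not among the compounds shown. So does the outcome for a phenyl ring carrying a carboxylic acid.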